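Trading 3-chlorophenyl for 2-fluorophenyl on compound 3

The source may hold more compounds than are shown below. What is called first, only, known or untested is meant among the compounds shown, and "the series" means these compounds.

Among the measured compounds shown here, in a functional assay on SGC-7901 cells (Homo sapiens) for antiproliferative activity, read by MTT assay, with a stated time of 24 h (a lower number here means a stronger inhibitor, a higher number a weaker inhibitor), compound 3 (`O=C(NNC(=O)c1ccccc1NS(=O)(=O)c1cnc(O)nc1O)c1cccc(Cl)c1`) gives 1820 nM, the only true number so far. Compound 1 (`Cc1ccccc1NNC(=O)c1ccccc1NS(=O)(=O)c1cnc(O)nc1O`) reaches only a limit of the assay, > 20000 nM. Compound 2 (`O=C(NNc1ccccc1Cl)c1ccccc1NS(=O)(=O)c1cnc(O)nc1O`) likewise reaches only a limit, > 20000 nM.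

Compound 4 (`O=C(NNC(=O)c1ccccc1NS(=O)(=O)c1cnc(O)nc1O)c1ccccc1F`), not yet measured, carries 2-fluorophenyl in place of 3-chlorophenyl on a carbonyl carbon.

For the measured compounds named here, two measured steps bear on it, both large: an at least 10-fold lower number from compound 1 to compound 3 (1.04 log units; beyond the scatter) and an at least 10-fold lower number from compound 2 to compound 3 (1.04 log units; beyond the scatter). Each puts (3-chlorophenyl)carbonyl in place of a substituted phenyl on an amine nitrogen, and compound 4 keeps a substituted phenyl carbonyl there. Going by the values given here, the remaining step, a step that the two limits leave unreadable from compound 1 to compound 2, cannot be read, and no measured step alters the ring on the carbonyl carbon. A number near that of compound 3 is therefore expected, with a 1.4-fold higher number from compound 3 to compound 4 (0.14 log units; within the scatter) as the estimated step, probably not beyond the scatter. For compound 4 the estimated value in this assay is 2500 nM, with an expected range of 700 nM to 9000 nM.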

Compound 4, half-maximal inhibitory concentration: > 20000 nM
Compound 4 ended at the assay's limit; the forecaster's own chance of this, stated with the estimate: 12%; middle value at least 8.0-fold (0.90 log units) from the limit.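

Putting 2-fluorophenyl in place of 3-chlorophenyl on a carbonyl carbon gives an at least 10-fold higher number from compound 3 to compound 4 (1.04 log units; beyond the scatter) in this assay. Among the compounds shown here, the earlier steps changed only the group on the amine nitrogen, so this is the first sign that the ring on the carbonyl carbon matters, and that a carbonyl at this place does not by itself secure a readable number. Compound 4 reaches only a limit of the assay, and the steps to it from compound 1 and compound 2 cannot be read: the limit of > 20000 nM in this assay, at which 3 of the 4 values shown sit.

Both the halogen and its ring position change in this one step, so the compounds shown leave open which of the two accounts for the loss. From the compounds shown here alone, how 3-fluorophenyl or unsubstituted phenyl on that carbonyl carbon would read also remains open.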